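Shortening the carbamate ester of compound 2: expected exposure

The source may report more compounds than this note shows. Statements on the series, on what has been measured and on what is new or still open speak of the compounds shown alone.

Measured compounds:
compound 1, `CCN1CCN(c2cc(Nc3cc(C)nn3C(=O)C(C)(C)C)nc(N[C@H]3CCN(C(=O)c4ccc(Cl)cc4F)C3)n2)CC1`, 401 ng.h/mL
compound 2, `CCN1CCN(c2cc(Nc3cc(C)nn3C(=O)OC(C)(C)C)nc(N[C@H]3CCN(C(=O)c4ccc(Cl)cc4F)C3)n2)CC1`, 780 ng.h/mL

In an ADME assay on the whole organism (Mus musculus, strain ICR) for pharmacokinetics, read by LC-MS, with a stated time of 24 h, at a dose of 2 mg/kg by the intravenous route (a lower number here means less compound in the circulation, a higher number more compound in the circulation at the dose given), compound 2 gives 780 ng.h/mL, the upper of the two numbers shown, with compound 1 at 401 ng.h/mL nearest to it; the one measured step, a 1.9-fold higher number from compound 1 to compound 2 (0.29 log units; within the scatter), does not separate them. Compound 3, `CCOC(=O)n1nc(C)cc1Nc1cc(N2CCN(CC)CC2)nc(N[C@H]2CCN(C(=O)c3ccc(Cl)cc3F)C2)n1`, differs from compound 2 by ethyl in place of tert-butyl on an oxygen next to a carbonyl group. No measured step covers this change; the single step shown touches the group on the carbonyl carbon and was small. Compound 3 is therefore expected to stay near compound 2 in this assay, with a 1.3-fold lower number from compound 2 to compound 3 (0.11 log units; within the scatter) meaning a step not beyond the scatter. The estimate for compound 3 is 600 ng.h/mL, between 250 ng.h/mL and 1500 ng.h/mL.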

Compound 3, area under the concentration-time curve: 1490 ng.h/mL
Compound 3: middle estimate off by 2.5-fold (0.40 log units), on the low side; the measured number falls inside the stated range.
By their numbers in this assay, from the lowest: compounds 1, 2 and 3 (each within the scatter of the next, the first and the last beyond it).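

In this assay, ethyl in place of tert-butyl on an oxygen next to a carbonyl group gives a 1.9-fold higher number from compound 2 to compound 3 (0.28 log units; within the scatter), so this change alone does not separate the two carbamates. Set against the tert-butyl on the carbonyl carbon, however, ethoxy gives a 3.7-fold higher number from compound 1 to compound 3 (0.57 log units; beyond the scatter), the first step at this position to clear the scatter, though only a modest one. Nothing available accounts for this step.

The compounds shown leave open how methoxy or a cyclopropyl ester would read in this assay. They also leave open whether an amine nitrogen in place of the ester oxygen would keep the number of compound 3.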